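Side-chain change from compound 3 to compound 4

The source may report more compounds than this note shows. Statements on the series, on what has been measured and on what is new or still open speak of the compounds shown alone.

Going by the values given here, the series so far holds compound 1 (`O=C(N/N=C/c1ccccc1)Nc1ccc(Oc2ccnc3[nH]ccc23)cc1`), compound 2 (`O=C(N/N=C/c1ccc([N+](=O)[O-])cc1)Nc1ccc(Oc2ccnc3[nH]ccc23)cc1`) and compound 3 (`CN(C)CCn1cccc1/C=N/NC(=O)Nc1ccc(Oc2ccnc3[nH]ccc23)cc1`). In a functional assay on MCF7 cells (Homo sapiens) for antiproliferative activity, read by MTT assay, with a stated time of 72 h (on this read-out lower numbers stand for stronger inhibition and higher numbers for weaker inhibition), compound 1 gives 1510 nM and compound 2 gives 15600 nM on the same read-out. For compound 3 the entry reads "not determined" (no result reported) and no number exists, so it has no place on the scale and offers no starting value.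

Compound 4 (`O=C(N/N=C/c1cccn1CCCN1CCCC1)Nc1ccc(Oc2ccnc3[nH]ccc23)cc1`) differs from compound 3 as follows: (pyrrolidin-1-yl)methyl in place of dimethylamino on a saturated chain carbon, two bonds along the chain from an aromatic nitrogen.

Among the compounds with values here, only one measured step exists: a 10-fold higher number from compound 1 to compound 2 (1.01 log units; beyond the scatter) for nitro in place of hydrogen on an aromatic carbon. That step is large, but it records a different change and does not bear on this one. Within the data shown here, with no number for compound 3 and no measured step of this kind, no size or direction of step can be expected in this assay here. The estimate therefore leans on the two measured numbers of the series, chiefly compound 1 at 1510 nM as the unsubstituted reference, and the range is kept wide. For compound 4 the expected value is 2500 nM with an estimated range from 400 nM to 15000 nM as a working figure.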

Compound 4, half-maximal inhibitory concentration: 4530 nM
Compound 4: the middle estimate sits 1.8-fold (0.26 log units) below what was measured; measured number inside the range.
By their numbers in this assay, from the lowest: compound 1; then compound 4; then compound 2.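

In this assay, going by these compounds alone, compound 4 gives 4530 nM but compound 3 carries no number on this scale, so no step from compound 3 to compound 4 can be read. The compounds shown leave open how the change from 2-(dimethylamino)ethyl to 3-(pyrrolidin-1-yl)propyl moves this read-out. No supporting data bear on this result.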